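The compounds below may be only part of what the source reports. "The series", "measured", "known", "first", "only" and "open" are said of these compounds alone.

Compounds measured in an assay on membranes from striatum with 5-hydroxytryptamine receptor 4 (Rattus norvegicus) as the target; on this read-out higher numbers stand for weaker inhibition and lower numbers for stronger inhibition:
- compound 1 `CS(=O)(=O)NCCN1CCC(CNC(=O)c2cc(Cl)cc3[nH]cnc23)CC1` — 0.11 nM
- compound 2 `CCCCN1CCC(CNC(=O)c2cc(Br)cc3[nH]cnc23)CC1` — 0.646 nM
- compound 3 `CCCCN1CCC(CNC(=O)c2cc(Cl)c([N+](=O)[O-])c3[nH]cnc23)CC1` — 44.7 nM

Compound 3 carries a nitro group that compounds 1 and 2 lack, and it gives the highest number of the three in this assay, far beyond the scatter from both compound 2 and compound 1. Compound 1 and compound 2 differ from each other in more than one place, so their values show only that both sit well below compound 3.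

Compound 4 `CCCCN1CCC(CNC(=O)c2cc(Br)c([N+](=O)[O-])c3[nH]cnc23)CC1` is the next step: bromo in place of chloro on an aromatic carbon. Going by the values given here, no measured pair in the set isolates this exchange. The halogen swap is expected to move the number little, if at all, beyond the scatter; compound 4 is estimated at 40 nM (range 15 nM to 120 nM), a step of a 1.1-fold lower number from compound 3 to compound 4 (0.05 log units; within the scatter) expected to stay within the scatter.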

Compound 4, inhibition constant: 47.9 nM
The estimate for compound 4 lay 1.2-fold (0.08 log units) below the measured number; measured number inside the range.
By their numbers in this assay, from the lowest: compound 1; then compound 2; then compounds 3 and 4 (each within the scatter of the next).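

In this assay bromo in place of chloro, ortho to a nitro group, gives a 1.1-fold higher number from compound 3 to compound 4 (0.03 log units; within the scatter) and the two halogens are not told apart at this position while the nitro group is present. Going by these compounds alone, with bromo held fixed, nitro in place of hydrogen gives a 74-fold higher number from compound 2 to compound 4 (1.87 log units; beyond the scatter) and this is the first reading of the nitro group as a single change, large and beyond the scatter. No measured property bears on either step.

Going by these compounds, whether bromo and chloro also match without the nitro group stays open. Also open, on these data alone, is how an amine or a methoxy group would read in place of the nitro group.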